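A few compounds are considered here, and "the series" means these few. Any claim that something is new, unique, unknown or untested is made for them only; others in the source may bear on it.

In an ADME assay on HEL cells (Homo sapiens) for cytotoxicity (a higher number here means that more compound is tolerated, a lower number that less compound is tolerated), two compounds have been measured so far:

compound 1, `O=C(COc1cccc2ccccc12)N/N=C/c1ccc(Cl)cc1`: 100 ug/mL
compound 2, `C/C(=N\NC(=O)COc1cccc2ccccc12)c1ccc(Cl)cc1`: >= 4 ug/mL

Compound 1 is the only one of the two that comes with an actual number; in this assay compound 1 gives 100 ug/mL, meaning the cells tolerate a fairly high amount of it. The result for compound 2 is not a number but a limit of the assay, (the limit of >= 4 ug/mL in this assay, at which 1 of the 2 values shown sits). Within the data shown here, the two results are of different kinds, so no step between measured compounds can be read from them. The two structures also differ in more than one place.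

The next compound, compound 3, `CSc1ccc(/C=N/NC(=O)COc2cccc3ccccc23)cc1`, has not yet been measured. It differs from compound 1 in a single place: methylsulfanyl in place of chloro on an aromatic carbon. Among the measured compounds shown here, with no measured step to lean on, the expectation rests on compound 1 alone. The step from compound 1 to compound 3 is expected to be small, no change at the digits printed from compound 1 to compound 3 (within the scatter), that is, within the scatter of repeated measurements rather than a real change in either direction. Compound 3 is therefore estimated at 100 ug/mL, with a likely range from 30 ug/mL to 200 ug/mL.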

Compound 3, minimum cytotoxic concentration: >= 100 ug/mL
Compound 3 gave a limit, no number (the forecaster's own chance of this, stated with the estimate: 35%); the middle value lies on the limit itself.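

At this place, on an aromatic carbon para to a large group, the cells lose no tolerance when methylsulfanyl, with its 2 heavy atoms, replaces the single chlorine of chloro. In this assay, the change gives a number no lower from compound 1 to compound 3 (the limit leaves the size open). Compound 3 carries a limit of the assay and not a number: >= 100 ug/mL. As far as these compounds go, the true size of the change stays unknown because the result sits on a limit: the limit of >= 100 ug/mL in this assay, at which 1 of the 3 values shown sits.

From the compounds shown here alone, whether an amine, a carboxylic acid or a longer chain such as butylsulfanyl at this same place would be tolerated as well as chloro and methylsulfanyl remains open. Also open, going by these compounds, is whether methylsulfanyl only matches chloro here or goes beyond it, which a real number for compound 3 would settle.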